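Aniline meta substituent: trifluoromethyl exchanged for bromo

A few compounds are considered here, and "the series" means these few. Any claim that something is new, unique, unknown or untested is made for them only; others in the source may bear on it.

Measured compounds in a functional assay on HGC-27 cells (Homo sapiens) for cytotoxicity, read by MTT assay, with a stated time of 72 h; a higher number here means a weaker inhibitor, a lower number a stronger inhibitor:
compound 1 `COc1ccccc1Nc1nc(SCc2ccc(C(F)(F)F)cc2)nc2ccccc12`: > 50000 nM.
compound 2 `CCOc1ccccc1Nc1nc(SCc2ccc(C(F)(F)F)cc2)nc2ccccc12`: > 50000 nM.
compound 3 `FC(F)(F)c1ccc(CSc2nc(Nc3cccc(C(F)(F)F)c3)c3ccccc3n2)cc1`: 11700 nM.

Compound 1 carries a value that is a limit of the assay, not a number. Compound 2 likewise carries a value that is a limit. For the measured compounds named here, compound 3 therefore carries the only actual number in this assay, and the two limits sit at the limit of > 50000 nM in this assay, at which 2 of the 3 values shown sit. The step of an at least 4.2-fold lower number from compound 1 to compound 3 (0.63 log units; beyond the scatter) and the step of an at least 4.2-fold lower number from compound 2 to compound 3 (0.63 log units; beyond the scatter) both reach past the limit and are at least modest in size, while the step that the two limits leave unreadable from compound 1 to compound 2 cannot be read between two limits.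

Compound 4 `FC(F)(F)c1ccc(CSc2nc(Nc3cccc(Br)c3)c3ccccc3n2)cc1` differs from compound 3 by bromo in place of trifluoromethyl on an aromatic carbon. Going by the values given here, no measured step touches only this position; the two readable steps exchange the whole aryl group on the nitrogen, and they leave the bromo case untested. Compound 3 is expected to change little in this assay on going to compound 4, a step estimated as a 1.0-fold higher number from compound 3 to compound 4 (0.01 log units; within the scatter), not beyond the scatter. Compound 4 is accordingly expected to give about 12000 nM in this assay, with a range from 4000 nM to 40000 nM.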

Compound 4, half-maximal inhibitory concentration: 18300 nM
Compound 4: middle estimate off by 1.5-fold (0.18 log units), on the low side; low and high end bracket the measured number.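

In this assay, the exchange gives a 1.6-fold higher number from compound 3 to compound 4 (0.19 log units; within the scatter), so this position does not separate bromo from trifluoromethyl, even though one heavy atom replaces four. The exchange of the whole aryl group on the nitrogen now has a second readable case, with 3-bromophenyl as well as 3-(trifluoromethyl)phenyl giving a number: an at least 2.7-fold lower number from compound 2 to compound 4 (0.43 log units; beyond the scatter), and an at least 2.7-fold lower number from compound 1 to compound 4 (0.43 log units; beyond the scatter). These two steps start from limits of the assay, not from numbers, so their true size remains unknown: the limit of > 50000 nM in this assay, at which 2 of the 4 values shown sit.

From the compounds shown here alone, whether this position also accepts an amine, a carboxylic acid or a longer chain in place of bromo remains open. The compounds shown also leave open how the result changes when the aryl group on the nitrogen is kept and the rest of the shared core is altered.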